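A few compounds are considered here, and "the series" means these few. Any claim that something is new, unique, unknown or untested is made for them only; others in the source may bear on it.

Working notes on the series. Three compounds share one core and differ at the saturated ring carbon that carries the side chain: compound 1 `CC1(Cc2ccc(C(F)(F)F)cc2)CC(S(=O)(=O)c2ccc(F)cc2)=C(c2ccc(/C(N)=N/O)cc2)O1`, compound 2 `CC1(Cc2ccccc2C(F)(F)F)CC(S(=O)(=O)c2ccc(F)cc2)=C(c2ccc(/C(N)=N/O)cc2)O1` and compound 3 `CC1(Cc2ccc(CO)cc2)CC(S(=O)(=O)c2ccc(F)cc2)=C(c2ccc(/C(N)=N/O)cc2)O1`. In an ADME assay on cells (Peritoneal macrophage, Mus musculus, strain Balb/c) for cytotoxicity, read by resazurin assay, with a stated time of 72 h (a higher number here means that more compound is tolerated, a lower number that less compound is tolerated), compound 1 gives 103000 nM. In this assay compound 2 gives 105000 nM. In this assay compound 3 gives only a limit, > 100000 nM; where it stands relative to the other two is therefore not readable, as noted in the limit of > 100000 nM in this assay, at which 1 of the 3 values shown sits.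

Among the measured steps, a 1.0-fold higher number from compound 1 to compound 2 (0.01 log units; within the scatter). The steps a step that the limit leaves unreadable from compound 1 to compound 3 and a step that the limit leaves unreadable from compound 2 to compound 3 both end at the limit.

Compound 4 `CC1(/C=C/c2ccc(C(F)(F)F)cc2)CC(S(=O)(=O)c2ccc(F)cc2)=C(c2ccc(/C(N)=N/O)cc2)O1` is the next step from compound 3: 2-(4-(trifluoromethyl)phenyl)ethenyl in place of 4-(hydroxymethyl)benzyl on a saturated ring carbon. Within the data shown here, none of the measured steps covers this change directly; the only readable one is the move of the trifluoromethyl group around the ring, which did nothing in this assay, and the two that replace it run into the limit. Among the measured compounds shown here, since every value so far sits at or near the top of the tested range, the expectation is that compound 4 also tolerates compound at a high level, with an at least 1.1-fold lower number from compound 3 to compound 4 (0.04 log units; that floor lies within the scatter), and that the assay may again report only a limit. The estimate for compound 4 is 90000 nM, with a range from 35000 nM to 200000 nM.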

Compound 4, half-maximal cytotoxic concentration: 43900 nM
Estimate against measurement, compound 4: 2.1-fold (0.31 log units) above; low and high end bracket the measured number.
By their numbers in this assay, from the lowest: compound 4; then compounds 1 and 2 (each within the scatter of the next).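

In this assay, among these compounds, this is the first change at the saturated ring carbon that lowers the tolerated concentration beyond the scatter, with a 2.3-fold lower number from compound 1 to compound 4 (0.37 log units; beyond the scatter) and a 2.4-fold lower number from compound 2 to compound 4 (0.38 log units; beyond the scatter). The 4-(trifluoromethyl)phenyl group is common to compound 1 and compound 4, so the step between them lies in the link to the ring carbon alone, 2-(4-(trifluoromethyl)phenyl)ethenyl replacing 4-(trifluoromethyl)benzyl, whereas moving the trifluoromethyl group around the ring stayed within the scatter. The step from compound 3 reads only as a minimum, an at least 2.2-fold lower number from compound 3 to compound 4 (0.35 log units; beyond the scatter), and the steps from compound 1 and compound 2 to compound 3 cannot be read, since compound 3 gives only a limit: the limit of > 100000 nM in this assay, at which 1 of the 4 values shown sits.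

The compounds shown leave open whether the double bond or the longer link carries the step, a question that a saturated 2-(4-(trifluoromethyl)phenyl)ethyl group on the same ring carbon would separate. Also open, from the compounds shown here alone, is whether hydroxymethyl, an amine or a carboxylic acid in place of trifluoromethyl on the ethenyl side chain would bring the number back towards that of compound 1.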